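The compounds below may be only part of what the source reports. "The series", "measured", "known", "first", "only" and "open" are said of these compounds alone.

Compound 3 `CC1CN(c2cccc(F)n2)NC(=O)N1` gives 6600 nM in an assay on RBL-1 cells for inhibition of Polyunsaturated fatty acid 5-lipoxygenase (Rattus norvegicus) (a lower number here means a stronger inhibitor, a higher number a weaker inhibitor), the second highest of three numbers. Compound 1 `O=C1NCCN(c2cccc(Cl)c2)N1` gives 5300 nM, which sits within the scatter of compound 3. Compound 2 `O=C1NCCN(c2cccc(O)c2)N1` gives 32000 nM, and the only single step shown, a 6.0-fold higher number from compound 1 to compound 2 (0.78 log units; beyond the scatter), replaces a halogen with a hydroxy group. Compound 4 `COc1cccc(N2CC(C)NC(=O)N2)n1` differs from compound 3 by methoxy in place of fluoro on an aromatic carbon. The hydroxy step bears only loosely on this, since methoxy is not hydroxy and the ring here carries a nitrogen, so a small weakening or no step beyond the scatter is expected. Compound 4 is therefore estimated at 9000 nM, within 3000 nM to 30000 nM, meaning an expected 1.4-fold higher number from compound 3 to compound 4 (0.13 log units; within the scatter).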

Compound 4, half-maximal inhibitory concentration: 5500 nM
For compound 4 the middle estimate is 1.6-fold (0.21 log units) above the measured one; low and high end bracket the measured number.
By their numbers in this assay, from the lowest: compounds 1, 4 and 3 (each within the scatter of the next); then compound 2.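

Methoxy in place of fluoro on this aromatic carbon, next to the ring nitrogen, gives a step that stays within the scatter in this assay (a 1.2-fold lower number from compound 3 to compound 4 (0.08 log units; within the scatter)). The earlier step, hydroxy in place of chloro (a 6.0-fold higher number from compound 1 to compound 2 (0.78 log units; beyond the scatter)), lay beyond the scatter, but it belongs to a different core, so it cannot be read across to this position. Here, two heavy atoms in place of one leave the number effectively unchanged, and no measurement available here explains this. From the compounds shown here alone, whether an amine or a longer chain such as ethoxy at this carbon would also stay within the scatter remains open. So does whether the same methoxy change would behave alike on the core of compound 1.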